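Swapping Dichlorophenyl for Methoxyphenyl on a Triazine Ether

The source may report more compounds than this note shows. Statements on the series, on what has been measured and on what is new or still open speak of the compounds shown alone.

This piece concerns a small series of compounds built on one shared core, carrying a three-carbon ether chain that ends in a substituted phenyl ring. Among the compounds with values here, compound 1, with the structure `NC1=NC2(CCOCC2)N(OCCCOc2ccc(Cl)c(Cl)c2)C(N)=N1`, is the only member with a reported number. In an assay on isolated protein for inhibition of Dihydrofolate reductase (Homo sapiens), read by spectrophotometry, using NADPH, with stated times of 5 s and 6 min (on this read-out higher numbers stand for weaker inhibition and lower numbers for stronger inhibition), compound 1 gives 8.23 nM, which places it as the lone reference point: the two related compounds, compound 2 `NC1=NC2(CCOCC2)N(OCCCOc2cccc(Cl)c2Cl)C(N)=N1` and compound 3 `NC1=NC2(CCOCC2)N(OCCCOc2ccccc2Br)C(N)=N1`, each carry a different pattern of halogens on the phenyl ring, but the assay result for compound 2 is "not determined" (no result reported). Compound 3 likewise gives "not determined" (no result reported), so no comparison among the measured entries is possible and no structure–activity step can be read from them.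

Compound 4, with the structure `COc1ccc(OCCCON2C(N)=NC(N)=NC23CCOCC3)cc1`, is not yet measured. Computed from the two structures, it differs from compound 1 in one place: 4-methoxyphenyl in place of 3,4-dichlorophenyl on an oxygen on a saturated carbon. Within the data shown here, no step between measured compounds is available to calibrate the effect of this change, so the expectation rests on the single anchor 8.23 nM of compound 1 and on the nature of the swap alone.

The expected step of a 5.5-fold higher number from compound 1 to compound 4 (0.74 log units; beyond the scatter) is a loss of inhibition that is likely to exceed the usual scatter. Compound 4 is therefore estimated at 45 nM, with a plausible range from 12 nM to 200 nM.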

Compound 4, half-maximal inhibitory concentration: 11.1 nM
For compound 4 the middle estimate is 4.1-fold (0.61 log units) above the measured one; measured number below the stated range.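

In this assay, putting 4-methoxyphenyl in place of 3,4-dichlorophenyl on an oxygen on a saturated carbon gives a 1.3-fold higher number from compound 1 to compound 4 (0.13 log units; within the scatter), so this read-out does not tell the two compounds apart. This position therefore accepts a ring with both chlorine atoms gone and a methoxy group present, even though the entering group counts a hydrogen-bond acceptor that the leaving group lacks, and inhibition of the enzyme stays in the same range. Nothing measured here explains why the two rings read alike.

Going by these compounds, since the two chlorine atoms leave and the methoxy group enters in a single swap, the separate contribution of each stays unknown, and a plain phenyl ring or a 4-chlorophenyl ring would be needed to pull them apart; the steps to compound 2 and compound 3 cannot be read, so the other halogen patterns offer no help. On these data alone, it also remains open how far this tolerance extends, for instance to a ring carrying a carboxylic acid or an amine, or to a longer chain between the ether oxygen and the ring.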